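Terminal Group Swap on an Alkoxy Chain

The compounds below may be only part of what the source reports. "The series", "measured", "known", "first", "only" and "open" are said of these compounds alone.

Compound 1, `C=CCc1cc(C(C)=O)c(O)cc1OCCCCC#N`, gives 57%.
Compound 2, `C=CCc1cc(C(C)=O)c(O)cc1OCCCCCCCCC#N`, gives 50%.
Compound 3, `C=CCCCCOc1cc(O)c(C(C)=O)cc1CC=C`, gives 27%.

All three numbers come from an assay on isolated protein for binding affinity to leukotriene B4 receptor 1 (Homo sapiens), tested at 1 uM; on this read-out lower numbers stand for less inhibition and higher numbers for more inhibition at the one concentration tested (going by the name of the read-out). Compound 3 stands lowest of the three measured compounds, and both steps into it lie beyond the scatter, while compound 1 and compound 2 sit within the scatter of each other: a number 7 percentage points lower from compound 1 to compound 2 (within the scatter).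

Compound 4, `C=CCc1cc(C(C)=O)c(O)cc1OCCCCCC(C)=O`, has not yet been measured. It differs from compound 3 by 2-oxopropyl in place of vinyl on a saturated chain carbon, four bonds along the chain from an oxygen on an aromatic ring. Within the data shown here, the steps that bear on this change are those that replaced a group carrying an acceptor at the same place with vinyl: a number 30 percentage points lower from compound 1 to compound 3 (beyond the scatter) and a number 23 percentage points lower from compound 2 to compound 3 (beyond the scatter). The incoming 2-oxopropyl again brings one hydrogen-bond acceptor to that position, so the change is expected to run the other way, partly recovering what was lost from compound 1 to compound 3. For compound 4 an estimated step of a number 18 percentage points higher from compound 3 to compound 4 (beyond the scatter) is therefore expected, giving an estimated value of 45% in this assay, within a range of 30% to 62%.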

Compound 4, a percentage reported as inhibition, at one concentration (the size of the read-out at that concentration, not a potency): 58%
For compound 4 the middle estimate is 13 percentage points below the measured one; low and high end bracket the measured number.
By their numbers in this assay, from the lowest: compound 3; then compounds 2, 1 and 4 (each within the scatter of the next).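

In this assay, among these compounds, the move to the 2-oxopropyl end gives a large step, a number 31 percentage points higher from compound 3 to compound 4 (beyond the scatter), so a nitrile is not the only end group that separates from vinyl at this place. The ketone-bearing chain also stays level with both nitrile chains, a number 1 percentage points higher from compound 1 to compound 4 (within the scatter) and a number 8 percentage points higher from compound 2 to compound 4 (within the scatter), leaving compound 3 as the only one of the four set apart, and it is also the only one whose chain end has no hydrogen-bond acceptor. Nothing measured here explains this difference.

Going by these compounds, whether a carboxylic acid or an amine at the same chain end would fall with compound 4 or with compound 3 remains open. So does whether a plain saturated alkyl end would match the vinyl end of compound 3.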